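The source may report more compounds than this note shows. Statements on the series, on what has been measured and on what is new or still open speak of the compounds shown alone.

The measured compounds in a functional assay on MGC-803 cells (Homo sapiens) for inhibition, read by sulforhodamine B assay; a lower number here means a stronger inhibitor, a higher number a weaker inhibitor:

compound 1, `COc1cccc(NC2=CC(=O)c3c(nc4n3[C@H]3OC[C@@H](O)[C@H]3OC4)C2=O)c1`, gives 1790 nM.
compound 2, `O=C1C(NC2CCCC2)=CC(=O)c2c1nc1n2[C@H]2OC[C@@H](O)[C@H]2OC1`, gives only a limit of the assay, > 16000 nM.
compound 3, `CCc1ccc(NC2=CC(=O)c3c(nc4n3[C@H]3OC[C@@H](O)[C@H]3OC4)C2=O)cc1`, gives 1110 nM.

Among the two numbers that were obtained, compound 3 stands lowest, but its nearest neighbour is compound 1, and the step of a 1.6-fold lower number from compound 1 to compound 3 (0.21 log units; within the scatter) lies within the scatter, so the two cannot be ordered. For the measured compounds named here, compound 2 stands apart as the one value recorded only as a limit, (the limit of > 16000 nM in this assay, at which 1 of the 3 values shown sits).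

Compound 4, `O=C1C(N2CCC2)=CC(=O)c2c1nc1n2[C@H]2OC[C@@H](O)[C@H]2OC1`, is reached from compound 3 by a single change: azetidin-1-yl in place of (4-ethylphenyl)amino on a double-bonded ring carbon. Going by the values given here, two measured steps bear on this. The step of an at least 8.9-fold higher number from compound 1 to compound 2 (0.95 log units; beyond the scatter) and the step of an at least 14-fold lower number from compound 2 to compound 3 (1.15 log units; beyond the scatter) both show that exchanging an aromatic amino substituent for a saturated ring on the same position moved the number beyond the scatter toward weaker inhibition, to the point that only a limit was recorded. Compound 4 carries a saturated ring as well, now without the amine hydrogen. The author therefore expects the step of an 18-fold higher number from compound 3 to compound 4 (1.26 log units; beyond the scatter) to be large and toward weaker inhibition. For compound 4 the estimate in this assay is 20000 nM, with a range from 5000 nM to 60000 nM, and a good chance that only a limit is reported.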

Compound 4, half-maximal inhibitory concentration: > 16000 nM
Compound 4: a limit, no number; the forecaster's own chance of this, stated with the estimate: 65%; the middle value does not contradict the limit.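

In this assay, azetidin-1-yl in place of an aromatic amino group on the double-bonded ring carbon gives an at least 14-fold higher number from compound 3 to compound 4 (1.15 log units; beyond the scatter), and against the other aromatic amine it gives an at least 8.9-fold higher number from compound 1 to compound 4 (0.95 log units; beyond the scatter). The earlier compounds shown here showed this kind of loss only with cyclopentylamino, which keeps the amine hydrogen, whereas compound 4 shows that a saturated ring attached through its own nitrogen, without that hydrogen and with a four-membered ring in place of a larger one, also ends at a limit. Compound 2 and compound 4 are both recorded only as limits, so the step between them cannot be read and any difference between these two saturated groups stays hidden: the limit of > 16000 nM in this assay, at which 2 of the 4 values shown sit.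

The compounds shown do not separate the loss of the aromatic ring from the loss of the amine hydrogen, since compound 4 loses both at once and compound 2 loses only the ring, yet both stop at the limit. An N-methyl-N-phenylamino group, which keeps the phenyl ring without the amine hydrogen, and a benzylamino group, which keeps both but moves the ring one carbon away from the nitrogen, would help to pull these apart.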